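Ring swap at the saturated carbon of compound 1

This account rests on a few compounds, and the source may have more. Where it says the series, first, only, none or still open, it means among the compounds named here.

Compound 1 `CCc1ccc(N(CC(C)C)S(=O)(=O)c2ccc3c(c2)C(O)CC(CC2CCOCC2)O3)cc1` gives 4.44 in a physicochemical assay for lipophilicity, at pH 7.4 (a lower number here means a more polar compound, a higher number a more lipophilic compound), the highest of the three numbers measured. Compound 2 `CC(C)CN(c1ccccc1C(F)(F)F)S(=O)(=O)c1ccc2c(c1)C(O)CC(C1CCOCC1)O2` gives 4.14, which sits within the scatter of compound 1. Compound 3 `O=S(=O)(c1ccc2c(c1)C(O)CC(C1CCOCC1)O2)N1CCC(c2ccccc2)CC1` gives 2.63, a number well beyond the scatter below compound 1. For the measured compounds named here, no pair among the measured compounds differs in one place, so no measured step exists for comparison.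

Compound 4 `CCc1ccc(N(CC(C)C)S(=O)(=O)c2ccc3c(c2)C(O)CC(C2CCN(C)CC2)O3)cc1` is the unmeasured analogue of compound 1, differing as follows: 1-methylpiperidin-4-yl in place of (oxan-4-yl)methyl on a saturated ring carbon. Going by the values given here, the change is a ring-for-ring exchange at the saturated ring carbon, with no measured precedent in this set. A downward step of substantial size is expected, a number 2.04 log units lower from compound 1 to compound 4 (beyond the scatter). Compound 4 is estimated at 2.4 in this assay, with a range from 1.6 to 3.2.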

Compound 4, distribution coefficient: 2.67
Beside the measured number, compound 4's estimate is 0.27 log units below it; measured number inside the range.
By their numbers in this assay, from the lowest: compounds 3 and 4 (each within the scatter of the next); then compounds 2 and 1 (each within the scatter of the next).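

In this assay, for the compounds shown here, the position on the saturated ring carbon responds strongly to this exchange: 1-methylpiperidin-4-yl in place of (oxan-4-yl)methyl gives a number 1.77 log units lower from compound 1 to compound 4 (beyond the scatter) as the first measured step here. The size of the step shows that the number at this position does not follow the counts, since both groups match in heavy atoms, hydrogen-bond donors and acceptors, and net charge. No available evidence bears on the origin of the step.

The exchange alters the ring hetero atom and the link to the core together, and the compounds shown do not separate the two. A (1-methylpiperidin-4-yl)methyl group at this position would divide the step between them.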